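From ethyl to tert-butoxycarbonyl on the ring nitrogen

This account rests on a few compounds, and the source may have more. Where it says the series, first, only, none or still open, it means among the compounds named here.

In a functional assay on MGC-803 cells (Homo sapiens) for inhibition, read by CCK-8 assay, with a stated time of 48 h (a higher number here means a weaker inhibitor, a lower number a stronger inhibitor), compound 1 `COc1ccc(CN(C(=O)CSc2nc3ccccc3o2)c2cc(OC)c(OC)c(OC)c2)cc1` gives 450 nM and compound 3 `COc1ccc(CN(C(=O)CSC(=S)N2CCN(C(C)=O)CC2)c2cc(OC)c(OC)c(OC)c2)cc1` gives 480 nM. These two stand level, with a 1.1-fold higher number from compound 1 to compound 3 (0.03 log units; within the scatter). Compound 2 `CCN1CCN(C(=S)SCC(=O)N(Cc2ccc(OC)cc2)c2cc(OC)c(OC)c(OC)c2)CC1`, at 9890 nM, has the highest number of the three and is the weakest inhibitor, with a 22-fold higher number from compound 1 to compound 2 (1.34 log units; beyond the scatter).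

Compound 4 `COc1ccc(CN(C(=O)CSC(=S)N2CCN(C(=O)OC(C)(C)C)CC2)c2cc(OC)c(OC)c(OC)c2)cc1` has not yet been measured. Compared with compound 2, it has tert-butoxycarbonyl in place of ethyl on an amine nitrogen in a ring.

The closest measured precedent is the exchange of ethyl for acetyl at that same nitrogen, which was a large step: a 21-fold lower number from compound 2 to compound 3 (1.31 log units; beyond the scatter). The step to compound 3 suggests that replacing ethyl at this nitrogen can lower the number substantially. For the measured compounds named here, it is, however, a single case, and no measured compound carries tert-butoxycarbonyl, so the full size of that step cannot be assumed to carry over. A large step towards a lower number is still expected, though probably somewhat smaller, and it is estimated as a 14-fold lower number from compound 2 to compound 4 (1.15 log units; beyond the scatter). The estimate for compound 4 is 700 nM, with the measurement expected to fall between 220 nM and 2500 nM.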

Compound 4, half-maximal inhibitory concentration: 310 nM
For compound 4 the middle estimate is 2.3-fold (0.35 log units) above the measured one, and the stated range covers the measured number.
By their numbers in this assay, from the lowest: compounds 4, 1 and 3 (each within the scatter of the next); then compound 2.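

In this assay, the large drop seen on replacing ethyl at this ring nitrogen is no longer a single case, since tert-butoxycarbonyl also gives a 32-fold lower number from compound 2 to compound 4 (1.50 log units; beyond the scatter). The result also shows that what stands on the carbonyl carbon makes no readable difference here, as tert-butoxy in place of methyl gives a 1.5-fold lower number from compound 3 to compound 4 (0.19 log units; within the scatter), which lies within the scatter, so that the two groups joined to the ring nitrogen through a carbonyl stand level, with compound 2 and its ethyl group alone at the weak end among these three. Why the carbonyl-linked groups differ so much from ethyl cannot be said, as nothing here speaks to a cause of this difference.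

Ethyl is the only group here without a carbonyl, so the compounds cannot show whether the carbonyl is what matters or whether ethyl is a particular liability. On these data alone, it remains open whether a bare ring amine, a methyl, a benzyl or a longer alkyl chain on this nitrogen would fall with compound 2, and whether a carbonyl group such as benzoyl or a urea would hold the level of compound 3 and compound 4.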